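The source may hold more compounds than are shown below. What is called first, only, known or untested is meant among the compounds shown, and "the series" means these compounds.

Compound 1 `COc1cc(C(=O)c2cn(-c3cccc(N)c3)cc2-c2ccccc2F)cc(OC)c1OC`: 34 nM
Compound 2 `COc1cc(C(=O)c2cn(-c3cccc(N)c3)cc2-c2ccccc2[N+](=O)[O-])cc(OC)c1OC`: 12 nM

In a functional assay on T-24 cells (Homo sapiens) for cytotoxicity, read by MTT assay, with a stated time of 48 h (on this read-out lower numbers stand for stronger inhibition and higher numbers for weaker inhibition), compound 1 stands as the higher of the two numbers, at 34 nM. Compound 3 `COc1cc(C(=O)c2cn(-c3cccc(N)c3)cc2-c2ccc(N)cc2)cc(OC)c1OC` differs from it as follows: 4-aminophenyl in place of 2-fluorophenyl on an aromatic carbon. Among the compounds with values here, the only measured step that bears on this change is a 2.8-fold lower number from compound 1 to compound 2 (0.45 log units; beyond the scatter), a modest one, with nitro in place of fluoro on an aromatic carbon. Within the data shown here, no measured compound carries 4-aminophenyl, so the direction remains open. A small step, perhaps none beyond the scatter, is expected: a 1.4-fold lower number from compound 1 to compound 3 (0.13 log units; within the scatter). Compound 3 is estimated at 25 nM, with an expected range of 6 nM to 100 nM.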

Compound 3, half-maximal inhibitory concentration: 12 nM
Compound 3: middle estimate off by 2.1-fold (0.32 log units), on the high side; measured number inside the range.
By their numbers in this assay, from the lowest: compounds 2 and 3 (each within the scatter of the next); then compound 1.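

In this assay, 4-aminophenyl in place of 2-fluorophenyl gives a 2.8-fold lower number from compound 1 to compound 3 (0.45 log units; beyond the scatter), so this position also accepts a group bearing an amine, not only 2-nitrophenyl. Exchanging 2-nitrophenyl for 4-aminophenyl gives no change at the digits printed from compound 2 to compound 3 (within the scatter), which leaves these two different replacements for 2-fluorophenyl level with each other. Nothing at hand accounts for this match. As far as these compounds go, whether 2-aminophenyl or 4-nitrophenyl would read the same remains open, so the identity of the added group is not separated from its place on the phenyl ring. From the compounds shown here alone, a 4-hydroxyphenyl or 4-carboxyphenyl group is equally open.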